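This account rests on a few compounds, and the source may have more. Where it says the series, first, only, none or still open, it means among the compounds named here.

Values in an ADME assay on HEK293 cells (Homo sapiens) for cytotoxicity, read by MTT assay, with a stated time of 24 h; a lower number here means a stronger inhibitor, a higher number a weaker inhibitor:

- compound 1 `COc1ccc(CNc2nc3ccc([N+](=O)[O-])cc3nc2NCCCN(C)C)cc1` gives 38.6 ug/mL
- compound 2 `CN(C)CCCNc1nc2cc([N+](=O)[O-])ccc2nc1NCc1ccccc1Br` gives 51.9 ug/mL

With only these two numbers in the series, compound 2 at 51.9 ug/mL stands level with compound 1 within the scatter, and neither can be ranked above the other. The next compound is compound 3 `COc1ccccc1CNc1nc2ccc([N+](=O)[O-])cc2nc1NCCCN(C)C`, and the change from compound 2 is methoxy in place of bromo on an aromatic carbon. In words, this is methoxy in place of bromo on an aromatic carbon, ortho to a large group, turning 2-bromobenzyl into 2-methoxybenzyl.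

Going by the values given here, one measured step bears on this: a 1.3-fold higher number from compound 1 to compound 2 (0.13 log units; within the scatter), which put 2-bromophenyl in place of 4-methoxyphenyl. That exchange of ring substituents left the number within the scatter. Among the compounds with values here, no measured pair compares 2-methoxyphenyl with 4-methoxyphenyl, so the evidence is thin and rests on a single step. No shift beyond the scatter is therefore expected in this assay, and the estimated step is a 1.2-fold lower number from compound 2 to compound 3 (0.06 log units; within the scatter). For compound 3 the expected value is 45 ug/mL, with an estimated range of 24 ug/mL to 85 ug/mL.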

Compound 3, half-maximal inhibitory concentration: 36.1 ug/mL
Compound 3: the middle estimate sits 1.2-fold (0.10 log units) above what was measured; measured number inside the range.
By their numbers in this assay, from the lowest: compounds 3, 1 and 2 (each within the scatter of the next).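

In this assay, the direct exchange of bromo for methoxy on an aromatic carbon, ortho to a large group, gives a 1.4-fold lower number from compound 2 to compound 3 (0.16 log units; within the scatter) and so leaves the number level at this position. The earlier step did not show this exchange alone. It also altered the ring substituent's place. Going by these compounds alone, compound 3 also provides the first comparison of one substituent at two ring places, and 2-methoxyphenyl in place of 4-methoxyphenyl gives a 1.1-fold lower number from compound 1 to compound 3 (0.03 log units; within the scatter) with the numbers again level. No measurement shown here accounts for either step, so the flat reading across compounds 1, 2 and 3 stays a description of these numbers alone.

Going by these compounds, it remains open whether a trifluoromethyl group, a carboxylic acid or a primary amine on the same aromatic carbon would shift the number beyond the scatter. The compounds shown also leave open what a longer chain in place of the dimethylaminopropyl side chain, or a nitrile in place of the nitro group on the shared core, would do in this assay with the benzyl part held constant.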